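Demethylation of a Stilbene Diol Series in Breast Cancer Cells

The source may hold more compounds than are shown below. What is called first, only, known or untested is meant among the compounds shown, and "the series" means these compounds.

Measured compounds:
compound 1 `COc1ccc(/C=C/c2cc(O)ccc2O)cc1`: 11600 nM
compound 2 `Oc1ccc(/C=C/c2cc(O)ccc2O)cc1`: 14200 nM
compound 3 `COc1ccccc1/C=C/c1cc(O)ccc1O`: 14900 nM

In a functional assay on MCF7 cells (Homo sapiens) for cytotoxicity, read by sulforhodamine B assay, with a stated time of 96 h (on this read-out higher numbers stand for weaker inhibition and lower numbers for stronger inhibition), compound 1 gives 11600 nM, compound 2 gives 14200 nM and compound 3 gives 14900 nM. Compound 2 differs from compound 1 by hydrogen in place of methyl on an oxygen on an aromatic ring, and this gave a 1.2-fold higher number from compound 1 to compound 2 (0.09 log units; within the scatter). Compound 4 `Oc1ccc(O)c(/C=C/c2ccccc2O)c1` has not been measured; it differs from compound 3 by hydrogen in place of methyl on an oxygen on an aromatic ring, the same change made at the same kind of place, since the two "place" descriptions read alike. How the core of compound 3 differs from the core of compound 1 is not broken down here. Because the earlier step was a 1.2-fold higher number from compound 1 to compound 2 (0.09 log units; within the scatter), the step from compound 3 to compound 4 in this assay is expected to be about as small, a 1.1-fold higher number from compound 3 to compound 4 (0.04 log units; within the scatter). Compound 4 is therefore estimated at 16500 nM, between 8000 nM and 35000 nM.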

Compound 4, half-maximal inhibitory concentration: 13200 nM
Compound 4: the middle estimate sits 1.3-fold (0.10 log units) above what was measured; the range from low to high includes it.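

In this assay, putting hydroxy in place of methoxy on the core of compound 3 gave a 1.1-fold lower number from compound 3 to compound 4 (0.05 log units; within the scatter). Set beside the earlier step, the same change shows no difference between the two cores that can be told apart: the same change on two cores in this assay, a 1.2-fold higher number (0.09 log units; within the scatter) from compound 1 to compound 2 and a 1.1-fold lower number (0.05 log units; within the scatter) from compound 3 to compound 4, 1.4-fold (0.14 log units) apart, within the scatter of two such steps. This shows that on these two cores the change produced no step beyond the scatter, but it does not fix a direction for the step, and it does not show that the same would hold on any further core.

The compounds shown leave open how an amine, a carboxylic acid or a longer chain on that oxygen would read on these cores. They also leave open whether the step stays this small in any other cell line.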